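The source may report more compounds than this note shows. Statements on the series, on what has been measured and on what is new or still open speak of the compounds shown alone.

Compound 3 `Cc1cc(S(=O)(=O)N2CCC(N3CCC(C)CC3)CC2)c(Cl)cc1Cl` stands beside compound 1 `Cc1noc(C)c1S(=O)(=O)N1CCC(N2CCC(C)CC2)CC1` and compound 2 `CC1CCN(C2CCN(S(=O)(=O)c3cccc(N)c3)CC2)CC1` as the measured members of the series. In an ADME assay on HCT-116 cells (Homo sapiens) for cytotoxicity, read by CellTiter-Glo, with a stated time of 72 h (a lower number here means a stronger inhibitor, a higher number a weaker inhibitor), compound 3 gives only a limit, > 5000 nM. Compound 1 likewise gives only a limit, > 10000 nM. Compound 2 also gives only a limit, > 5000 nM. Two lines sum up where the measured values sit: the limit of > 10000 nM in this assay, at which 1 of the 3 values shown sits, and (the limit of > 5000 nM in this assay, at which 2 of the 3 values shown sit). For the measured compounds named here, the single measured step, a step that the two limits leave unreadable from compound 1 to compound 2, is unreadable because both of its values are limits. Compound 4 `CC1CCN(C2CCN(S(=O)(=O)c3ccc(Cl)cc3Cl)CC2)CC1` differs from compound 3 by hydrogen in place of methyl on an aromatic carbon. Going by the values given here, no measured step bears on this change. Compound 4 is expected to remain at a limit as well, around 10000 nM within 5000 nM to 50000 nM. The expected step, no change beyond the scatter, is a step that the limit leaves unreadable from compound 3 to compound 4.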

Compound 4, half-maximal inhibitory concentration: > 5000 nM
Compound 4 was reported as a limit; the forecaster's own chance of this, stated with the estimate: 85%; the middle value is on the limit's open side.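

For the compounds shown here, no step from compound 1, compound 2 or compound 3 to compound 4 can be read in this assay: all four compounds give only limits. The compounds shown leave open whether any group on the sulfonyl sulfur gives a measurable value in this assay.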